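The compounds below may be only part of what the source reports. "The series", "measured", "known", "first", "only" and "open" are said of these compounds alone.

In an ADME assay on SH-SY5Y cells (Homo sapiens) for cytotoxicity, read by MTT assay, with a stated time of 72 h (on this read-out lower numbers stand for stronger inhibition and higher numbers for weaker inhibition), three compounds have been measured:

Compound 1 `Cc1ccc(C(=O)N2CCN(CC(=O)N3CCN(CCCc4c[nH]c5ccccc45)CC3)CC2)cc1`: > 200000 nM (a limit of the assay)
Compound 2 `O=C(CN1CCN(C(=O)c2ccc(Br)cc2)CC1)N1CCN(CCCc2c[nH]c3ccc(F)cc23)CC1`: 47400 nM
Compound 3 `Cc1ccc(C(=O)N2CCN(CC(=O)N3CCN(CCCc4c[nH]c5ccc(F)cc45)CC3)CC2)cc1`: 119000 nM

Compound 3, at 119000 nM, has the higher of the two true numbers, and its nearest neighbour is compound 2 at 47400 nM. Compound 1 reports only a limit, > 200000 nM.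

The next compound is compound 4 `O=C(CN1CCN(C(=O)c2cccc(Br)c2)CC1)N1CCN(CCCc2c[nH]c3ccc(F)cc23)CC1`, and the change from compound 3 is 3-bromophenyl in place of 4-methylphenyl on a carbonyl carbon. Two measured steps can be set against it. The first is an at least 1.6-fold lower number from compound 1 to compound 3 (0.22 log units; that floor lies within the scatter), with fluoro in place of hydrogen on an aromatic carbon. That change lies elsewhere in the molecule, and its floor falls within the scatter, so it offers no guide here. The second is a 2.5-fold higher number from compound 2 to compound 3 (0.40 log units; beyond the scatter), with methyl in place of bromo on an aromatic carbon, a modest step. The new change runs the opposite way, from a methyl-bearing ring to a bromo-bearing one, but it is no plain reversal, since the group entering is 3-bromophenyl. A modest move to a lower number in this assay is therefore expected, though with little certainty, as it rests on one step.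

The expected change is a 2.2-fold lower number from compound 3 to compound 4 (0.34 log units; beyond the scatter).

For compound 4 the estimated value is 55000 nM, with an expected range of 24000 nM to 120000 nM.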

Compound 4, half-maximal inhibitory concentration: 71600 nM
Compound 4: the middle estimate sits 1.3-fold (0.11 log units) below what was measured; low and high end bracket the measured number.
By their numbers in this assay, from the lowest: compounds 2, 4 and 3 (each within the scatter of the next, the first and the last beyond it). At a limit, above all of these: compound 1.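

On this carbonyl carbon, 3-bromophenyl in place of 4-methylphenyl gives a 1.7-fold lower number from compound 3 to compound 4 (0.22 log units; within the scatter) in this assay, so this exchange of ring groups has no readable effect on its own. Setting 3-bromophenyl against 4-bromophenyl gives a 1.5-fold higher number from compound 2 to compound 4 (0.18 log units; within the scatter) in the same way, so this pair offers no sign that the two bromophenyl groups differ in this assay. Compound 4 therefore cannot be placed in order against either neighbour, even though a 2.5-fold higher number from compound 2 to compound 3 (0.40 log units; beyond the scatter) keeps those two neighbours apart, and no measurement shown here offers an explanation for these numbers.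

The compounds shown leave open how 3-methylphenyl, a chlorophenyl or a pyridine ring on this carbonyl carbon would read, and whether an amine or a carboxylic acid on the ring would carry the number beyond the scatter from compound 3. Among the compounds shown here, they also leave open whether 3-bromophenyl would give a comparable number on the core without the fluoro group, or with a longer chain in place of the one shared by these compounds.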